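From compound 2 to compound 4: one group exchanged

The source may hold more compounds than are shown below. What is called first, only, known or untested is meant among the compounds shown, and "the series" means these compounds.

Measured so far in a physicochemical assay for solubility, measured as thermodynamic solubility, at pH 7.4; a higher number here means a more soluble compound, a lower number a less soluble compound
- compound 1 `CC(=O)N1CCN(c2nc(NC(c3ccccc3)c3ccccc3)c3c(n2)C(=O)N(C(C)C)C3)CC1` gives < 1000 nM
- compound 2 `CC(=O)N1CCN(c2nc(NCC3(c4ccc(Cl)cc4)CCC3)c3c(n2)C(=O)N(C(C)C)C3)CC1` gives 46000 nM
- compound 3 `CCOc1ccc([C@@H](CC)Nc2nc(N3CCN(C(C)=O)CC3)nc3c2CN(C(C)C)C3=O)cc1` gives 86000 nM

The entry for compound 1 is a limit and not a number. Compound 2 at 46000 nM and compound 3 at 86000 nM lie within the scatter of each other.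

Against compound 2, the unmeasured compound 4 `CC(=O)N1CCN(c2nc(NCc3cnc4ccccc4c3)c3c(n2)C(=O)N(C(C)C)C3)CC1` carries quinolin-3-yl in place of 1-(4-chlorophenyl)cyclobutyl on a saturated chain carbon bound to a nitrogen on an aromatic ring. Among the measured compounds shown here, no measured pair isolates this change, and no step beyond the scatter is expected in this assay for it. The expected step runs a 1.2-fold lower number from compound 2 to compound 4 (0.06 log units; within the scatter) as a working estimate. Compound 4 is estimated at 40000 nM with an expected range of 8000 nM to 150000 nM for now.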

Compound 4, solubility: 3000 nM
For compound 4 the middle estimate is 13-fold (1.12 log units) above the measured one; the measured number lies below the stated range.
By their numbers in this assay, from the lowest: compound 4; then compounds 2 and 3 (each within the scatter of the next). At a limit, below all of these: compound 1.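

In this assay, among the compounds shown here, this is the first measured single exchange on the saturated chain carbon bound to a nitrogen on an aromatic ring, and it gives a 15-fold lower number from compound 2 to compound 4 (1.19 log units; beyond the scatter). The entering quinolin-3-yl holds a hydrogen-bond acceptor and the leaving group none, yet the number falls. Compound 1 alone stands at a limit, not a number: the limit of < 1000 nM in this assay, at which 1 of the 4 values shown sits.

Which part of the exchange carries the step stays open: the ring nitrogen, the chlorine or the cyclobutyl ring. Naphthalen-2-yl, or quinolin-3-yl bearing an amine, at this place would help separate these.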